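Adding cyclohexyl to compound 2: a cytotoxicity estimate

This account rests on a few compounds, and the source may have more. Where it says the series, first, only, none or still open, it means among the compounds named here.

- Compound 1 `CC(=O)c1ccc2[nH]c(-c3ccc(C(F)(F)F)cc3)nc2c1` gives > 100000 nM as a limit
- Compound 2 `C/C(=N\NC(N)=O)c1ccc2[nH]c(-c3ccc(C(F)(F)F)cc3)nc2c1` gives > 100000 nM as a limit
- Compound 3 `C/C(=N\NC(N)=S)c1ccc2[nH]c(-c3ccc(C(F)(F)F)cc3)nc2c1` gives 5000 nM as a number

In an ADME assay on BHK-21 cells (Mesocricetus auratus) for cytotoxicity, read by MTT assay (a lower number here means that less compound is tolerated, a higher number that more compound is tolerated), compound 2 stands at the limit of > 100000 nM in this assay, at which 2 of the 3 values shown sit, and so has only a limit, not a number. Compound 4 `C/C(=N\NC(N)=O)c1ccc2c(c1)nc(-c1ccc(C(F)(F)F)cc1)n2C1CCCCC1` differs from compound 2 by cyclohexyl in place of hydrogen on an aromatic nitrogen and in no other place. Going by the values given here, none of the measured steps touches this nitrogen. They are a step that the two limits leave unreadable from compound 1 to compound 2 and an at least 20-fold lower number from compound 1 to compound 3 (1.30 log units; beyond the scatter) as well as an at least 20-fold lower number from compound 2 to compound 3 (1.30 log units; beyond the scatter) on exchanging oxygen for sulfur. Compound 3 at 5000 nM shows that a compound on this core can give a measured number, but it carries the sulfur that compound 4 lacks. A fall smaller than the steps to compound 3 is therefore expected, and the limit may well hold again. Expected in size and direction is an at least 1.6-fold lower number from compound 2 to compound 4 (0.22 log units; that floor lies within the scatter) and this remains uncertain. In this assay the estimated value for compound 4 is 60000 nM with an expected range from 20000 nM to 100000 nM until it is measured.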

Compound 4, half-maximal cytotoxic concentration: > 100000 nM
Compound 4: a limit, no number; the forecaster's own chance of this, stated with the estimate: 45%; middle value at least 1.6-fold (0.22 log units) away from the limit.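

In this assay compound 2 and compound 4 both give a limit and not a number, so no step between them can be read: the limit of > 100000 nM in this assay, at which 3 of the 4 values shown sit.

The compounds shown leave open whether cyclohexyl in place of hydrogen on this aromatic nitrogen changes the tolerated concentration at all.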